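Compound 1 to compound 4: fluoro in place of methyl

The source may report more compounds than this note shows. Statements on the series, on what has been measured and on what is new or still open speak of the compounds shown alone.

Compound 1 `Cc1ccc2c(c1)/C(=C1/Nc3ccccc3/C1=N\O)C(=O)N2Cc1ccc(/C=C/C(=O)NO)cc1` gives 60 nM in a functional assay on PC-3 cells (Homo sapiens) for cytotoxicity, read by colorimetric assay (on this read-out higher numbers stand for weaker inhibition and lower numbers for stronger inhibition), and stands level with compound 3 `O=C(NO)c1ccc(CN2C(=O)/C(=C3\Nc4ccccc4\C3=N/O)c3cccc(Cl)c32)cc1` at 60 nM while compound 2 `Cc1ccc2c(c1)/C(=C1/Nc3ccccc3/C1=N\O)C(=O)N2Cc1ccc(C(=O)NO)cc1` gives 90 nM within the scatter of both. Going by the values given here, compound 4 `O=C(/C=C/c1ccc(CN2C(=O)/C(=C3\Nc4ccccc4\C3=N/O)c3cc(F)ccc32)cc1)NO` keeps the 2-(hydroxycarbamoyl)ethenyl group of compound 1 and differs by fluoro in place of methyl on an aromatic carbon as its single change. Among the compounds with values here, the one measured step, a 1.5-fold higher number from compound 1 to compound 2 (0.18 log units; within the scatter), concerns that side group and not the place of the new fluoro, so it bears only indirectly. It shows how narrow the numbers are so far. Within the data shown here, no measured step isolates the exchange of methyl for fluoro, and the estimate therefore has a wide range. No step beyond the scatter is expected in this assay and the estimated step is no change at the digits printed from compound 1 to compound 4 (within the scatter) on this reasoning. Compound 4 is expected at 60 nM and the estimated range runs from 25 nM to 140 nM for repeat measurements.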

Compound 4, half-maximal inhibitory concentration: 50 nM
Beside the measured number, compound 4's estimate is 1.2-fold (0.08 log units) above it; measured number inside the range.
By their numbers in this assay, from the lowest: compounds 4, 1, 3 and 2 (each within the scatter of the next).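

In this assay, going by these compounds alone, fluoro in place of methyl on the aromatic carbon meta to a fused ring and para to a fused ring gives a 1.2-fold lower number from compound 1 to compound 4 (0.08 log units; within the scatter), the only measured step that isolates this exchange. With the 2-(hydroxycarbamoyl)ethenyl group held constant, methyl and fluoro at this position cannot be told apart on this read-out, so the position accepts this exchange without a step beyond the scatter. No accompanying measurement speaks to the reason for this result.

Going by these compounds, whether a methoxy group, an amine or a carboxylic acid at this position would stay level with compound 1 remains open. Also open, on these data alone, is whether the same exchange reads alike with the hydroxycarbamoyl side group of compound 2.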